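A few compounds are considered here, and "the series" means these few. Any claim that something is new, unique, unknown or untested is made for them only; others in the source may bear on it.

Measured in an assay on CHO cells for displacement of a labelled ligand from adenosine receptor A1 (Homo sapiens); a lower number here means a stronger inhibitor, a higher number a weaker inhibitor:
Compound 1, `CCn1cnc2ncnc(N)c21`, gives > 100000 nM, which is a limit of the assay rather than a number.
Compound 2, `Nc1ncnc2ncn(CCO)c12`, gives > 100000 nM, likewise a limit.
Among the compounds with values here, compound 3, `CC(O)Cn1c(Br)nc2c(N)ncnc21`, gives 2900 nM, the only number among the three.

Compound 2 differs from compound 1 by hydroxy in place of hydrogen on a saturated chain carbon, two bonds along the chain from an aromatic nitrogen. The step that the two limits leave unreadable from compound 1 to compound 2 cannot be read because the limit of > 100000 nM in this assay, at which 2 of the 3 values shown sit, covers both ends of it. Compound 4, `Nc1ncnc2c1nc(Br)n2CC(O)CO`, is not yet measured; it differs from compound 3 by hydroxy in place of hydrogen on a saturated chain carbon, two bonds along the chain from an oxygen on a saturated carbon. Within the data shown here, this is the same kind of change as the one from compound 1 to compound 2, though not the same: there the place was two bonds along the chain from an aromatic nitrogen, here it is two bonds along the chain from an oxygen on a saturated carbon. How the core of compound 3 differs from that of compound 1 is not broken down here. Since a step that the two limits leave unreadable from compound 1 to compound 2 gives no readable size, the step of a 1.4-fold higher number from compound 3 to compound 4 (0.14 log units; within the scatter) in this assay is expected to be small. Compound 4 is therefore expected to give about 4000 nM, between 1000 nM and 20000 nM.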

Compound 4, inhibition constant: 16000 nM
Compound 4: middle estimate off by 4.0-fold (0.60 log units), on the low side, within the range that was stated.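

On the core of compound 3, replacing 2-hydroxypropyl with 2,3-dihydroxypropyl gives a 5.5-fold higher number from compound 3 to compound 4 (0.74 log units; beyond the scatter) in this assay. This shows a modest weakening for this single pair, but not that the change carries the same size from one core to another, since the step on the core of compound 1 cannot be read: the limit of > 100000 nM in this assay, at which 2 of the 4 values shown sit. The two changes also differ in place, one lying two bonds along the chain from an aromatic nitrogen and the other two bonds along the chain from an oxygen on a saturated carbon.

The compounds shown leave open how an amine, a carboxylic acid or a longer chain would compare with the hydroxy that enters in compound 4. They also leave open how a 2,3-dihydroxypropyl chain would read on the core of compound 1.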